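A Second Chloro Group Added to Compound 2

The source may report more compounds than this note shows. Statements on the series, on what has been measured and on what is new or still open speak of the compounds shown alone.

Three compounds have been measured in a functional assay on HEK293 cells for agonist activity at Neuronal acetylcholine receptor; alpha4/beta2 (Homo sapiens), read by FLIPR; a higher number here means that more compound is needed for the effect, a lower number that less compound is needed:

Compound 1, `c1cncc(N2C[C@@H]3CCNC[C@@H]32)c1`, gives 410 nM.
Compound 2, `Clc1ccc(N2C[C@@H]3CCNC[C@@H]32)cn1`, gives 37.4 nM.
Compound 3, `Clc1ccc(N2C[C@H]3CCNC[C@H]32)cn1`, gives 216 nM.

Compound 2 has the lowest number of the three, so it needs the least material for the effect. The step of an 11-fold lower number from compound 1 to compound 2 (1.04 log units; beyond the scatter) shows what a single chloro group in place of hydrogen did. The step of a 5.8-fold higher number from compound 2 to compound 3 (0.76 log units; beyond the scatter) is a change in the opposite direction that rests on (the fact that compounds 2 and 3 differ only in the configuration as drawn).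

Compound 4, `Clc1cc(N2C[C@@H]3CCNC[C@@H]32)cnc1Cl`, has not been measured. It differs from compound 2 by chloro in place of hydrogen on an aromatic carbon. Of the measured steps only an 11-fold lower number from compound 1 to compound 2 (1.04 log units; beyond the scatter) involves a chloro group, and it was large, but it put the first chloro onto a ring that had none, whereas compound 4 adds a second one at a different place. It is therefore expected that this assay shows a step of a 1.6-fold higher number from compound 2 to compound 4 (0.21 log units; within the scatter), a change that may stay within the scatter or drift towards a somewhat higher number. The estimate for compound 4 is 60 nM, with a range from 15 nM to 250 nM.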

Compound 4, half-maximal effective concentration: 271 nM
The estimate for compound 4 lay 4.5-fold (0.65 log units) below the measured number, outside the stated range (above it).
By their numbers in this assay, from the lowest: compound 2; then compounds 3, 4 and 1 (each within the scatter of the next).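

A chloro group does not bring the same change wherever it goes on this ring. In this assay, the first one gave an 11-fold lower number from compound 1 to compound 2 (1.04 log units; beyond the scatter), whereas the second, placed ortho to a chloro group and two atoms from the ring nitrogen, gave a 7.2-fold higher number from compound 2 to compound 4 (0.86 log units; beyond the scatter), so the two steps run in opposite directions. Going by these compounds alone, until now the only rise from compound 2 was a 5.8-fold higher number from compound 2 to compound 3 (0.76 log units; beyond the scatter), which came from inverting all stereocentres, so this is the first rise from compound 2 with the configuration as drawn kept and a change made on the aromatic ring instead; nothing known about these compounds explains this rise.

On these data alone, what stays open is whether the rise belongs to chloro itself or would also follow from another group at this place, such as fluoro, methyl, methoxy or an amine. Also open, as far as these compounds go, is whether chloro at this place would raise the number on a ring without the first chloro group, and whether the mirror image of compound 4 would stand apart from it as compound 3 does from compound 2.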